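The source may report more compounds than this note shows. Statements on the series, on what has been measured and on what is new or still open speak of the compounds shown alone.

For the measured compounds named here, compound 2, `Fc1ccc(CSc2nnc(-c3ccncc3)n2-c2ccccc2)c(F)c1`, gives 11400 nM in a functional assay on HCT-116 cells (Homo sapiens) for inhibition, read by MTT assay, with a stated time of 48 h (a higher number here means a weaker inhibitor, a lower number a stronger inhibitor), the lower of the two numbers so far, though its separation from compound 1 is within the scatter. Compound 1, `Fc1ccccc1CSc1nnc(-c2ccncc2)n1-c1ccccc1`, gives 12000 nM in this assay. Going by the values given here, the single measured step, a 1.1-fold lower number from compound 1 to compound 2 (0.02 log units; within the scatter), changes nothing beyond the scatter. Compound 3, `O=[N+]([O-])c1ccc(CSc2nnc(-c3ccncc3)n2-c2ccccc2)cc1`, differs from compound 2 by 4-nitrophenyl in place of 2,4-difluorophenyl on a saturated chain carbon bound to a sulfur. The step from compound 1 to compound 2 is the only one that bears on it, since it also alters the ring on the saturated chain carbon bound to a sulfur, and it was flat; yet it exchanged only hydrogen for fluoro, whereas here the whole ring substitution pattern changes, so the guide is weak. No step beyond the scatter is expected, and the estimated shift a 1.0-fold lower number from compound 2 to compound 3 (0.02 log units; within the scatter) is small. Compound 3 is expected to give 11000 nM in this assay, within 4000 nM to 30000 nM.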

Compound 3, half-maximal inhibitory concentration: 23800 nM
Compound 3: middle estimate off by 2.2-fold (0.34 log units), on the low side; low and high end bracket the measured number.
By their numbers in this assay, from the lowest: compounds 2, 1 and 3 (each within the scatter of the next, the first and the last beyond it).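

In this assay, changing the ring on the saturated chain carbon bound to a sulfur proved able to move the number beyond the scatter, which the earlier fluoro step did not show: 4-nitrophenyl in place of 2,4-difluorophenyl gives a 2.1-fold higher number from compound 2 to compound 3 (0.32 log units; beyond the scatter) as a modest step. The same kind of exchange starting from 2-fluorophenyl gives a 2.0-fold higher number from compound 1 to compound 3 (0.30 log units; within the scatter) and stays within the scatter, so the change sits at the edge of what can be read and its size depends on which fluorinated ring it replaces. Nothing at hand accounts for the higher number of compound 3.

The compounds shown leave open whether that number goes with the nitro group itself or with the loss of fluoro. They also leave open how an amine or a carboxylic acid on this ring, or a longer chain at this place, would read.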